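Acetyl in place of chloro: what to expect

A few compounds are considered here, and "the series" means these few. Any claim that something is new, unique, unknown or untested is made for them only; others in the source may bear on it.

In a functional assay on MCF7 cells (Homo sapiens) for antiproliferative activity, read by MTT assay, with a stated time of 72 h (on this read-out higher numbers stand for weaker inhibition and lower numbers for stronger inhibition), compound 1 `Nc1nc(N)c2cc(CSC(=S)N3CCN(C4CCCCC4)CC3)ccc2n1` gives 6800 nM, compound 2 `Cc1ccc(N2CCN(C(=S)SCc3ccc4nc(N)nc(N)c4c3)CC2)c(C)c1` gives 3120 nM and compound 3 `Nc1nc(N)c2cc(CSC(=S)N3CCN(c4ccc(Cl)cc4)CC3)ccc2n1` gives 4880 nM. Compound 3 stands level with both of the others, since a 1.4-fold lower number from compound 1 to compound 3 (0.14 log units; within the scatter) and a 1.6-fold higher number from compound 2 to compound 3 (0.19 log units; within the scatter) stay within the scatter. Compound 4 `CC(=O)c1ccc(N2CCN(C(=S)SCc3ccc4nc(N)nc(N)c4c3)CC2)cc1` carries acetyl in place of chloro on an aromatic carbon, para to a large group: acetyl in place of chloro on an aromatic carbon. The measured steps all change the group on the same ring nitrogen, and the biggest, a 2.2-fold lower number from compound 1 to compound 2 (0.34 log units; beyond the scatter), is only modest. None of them tests an acetyl group, so no step beyond the scatter is expected in this assay. For compound 4 the estimate is 4200 nM, with an expected range from 1800 nM to 9500 nM. The estimated step is a 1.2-fold lower number from compound 3 to compound 4 (0.07 log units; within the scatter).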

Compound 4, half-maximal inhibitory concentration: 2490 nM
Estimate against measurement, compound 4: 1.7-fold (0.23 log units) above, within the range that was stated.
By their numbers in this assay, from the lowest: compounds 4, 2, 3 and 1 (each within the scatter of the next, the first and the last beyond it).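

Acetyl on the aromatic carbon para to a large group gives a 2.0-fold lower number from compound 3 to compound 4 (0.29 log units; within the scatter) in this assay, so this position takes acetyl in place of chloro with no step beyond the scatter. Compound 4 also stands level with the 2,4-dimethylphenyl compound, showing a 1.3-fold lower number from compound 2 to compound 4 (0.10 log units; within the scatter) here. Like compound 2 but unlike compound 3, it clears the scatter against the cyclohexyl compound, with a 2.7-fold lower number from compound 1 to compound 4 (0.44 log units; beyond the scatter) in this comparison.

As far as these compounds go, whether an amine or a carboxylic acid on this carbon would stay level with chloro remains open. Nothing shown here explains these steps.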